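The compounds below may be only part of what the source reports. "The series", "measured", "known", "first", "only" and "open" are said of these compounds alone.

In an assay on blood for inhibition of C-X-C chemokine receptor type 3 (Homo sapiens), with a stated time of 30 min (on this read-out lower numbers stand for stronger inhibition and higher numbers for weaker inhibition), compound 3 `Cc1nc(C)n(CC(=O)N2CCN(c3sc(C(F)(F)F)nc3-c3cnc(C4CC4)nc3)C[C@H]2C)n1` gives 674 nM. Compound 1 `COc1ncc(-c2nc(C(F)(F)F)sc2N2CCN(C(=O)Cn3nc(C)nc3C)[C@H](C)C2)cn1` gives 1040 nM and compound 2 `CCCc1ncc(-c2nc(C(F)(F)F)sc2N2CCN(C(=O)Cn3nc(C)nc3C)[C@H](C)C2)cn1` gives 367 nM in this assay, so compound 3 holds the second highest of the three numbers, with a 1.5-fold lower number from compound 1 to compound 3 (0.19 log units; within the scatter) and a 1.8-fold higher number from compound 2 to compound 3 (0.26 log units; within the scatter) both within the scatter. Compound 4 `Cc1nc(C)n(CC(=O)N2CCN(c3sc(C(F)(F)F)nc3-c3cnc(N4CCCC4)nc3)C[C@H]2C)n1` differs from compound 3 by pyrrolidin-1-yl in place of cyclopropyl on an aromatic carbon. Within the data shown here, no measured step involves pyrrolidin-1-yl; the exchanges at this carbon seen so far, a 2.8-fold lower number from compound 1 to compound 2 (0.45 log units; beyond the scatter) together with the two steps within the scatter just named, have moved this assay only modestly at most. The step of a 1.1-fold lower number from compound 3 to compound 4 (0.05 log units; within the scatter) is therefore expected to fall within the scatter. The estimate for compound 4 in this assay is 600 nM, with a range from 250 nM to 1500 nM.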

Compound 4, half-maximal inhibitory concentration: 352 nM
Compound 4: the middle estimate sits 1.7-fold (0.23 log units) above what was measured, and the stated range covers the measured number.
By their numbers in this assay, from the lowest: compounds 4, 2, 3 and 1 (each within the scatter of the next, the first and the last beyond it).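

In this assay, the carbon between two ring nitrogen atoms accepts pyrrolidin-1-yl, a larger ring that brings in a nitrogen, with no step beyond the scatter from the carbon-linked groups: the steps of a 1.9-fold lower number from compound 3 to compound 4 (0.28 log units; within the scatter) and a 1.0-fold lower number from compound 2 to compound 4 (0.02 log units; within the scatter) both lie within it. The step of a 3.0-fold lower number from compound 1 to compound 4 (0.47 log units; beyond the scatter) is modest but beyond the scatter. No evidence at hand gives a reason for these numbers. Still open, going by these compounds, is whether a morpholine ring, a carboxylic acid or a simple methylamino group on this carbon would give a similar number.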